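Swapping trifluoromethoxy for methoxy in a level series

The compounds below may be only part of what the source reports. "The series", "measured", "known", "first", "only" and "open" are said of these compounds alone.

Measured in a functional assay on HeLa cells (Homo sapiens) for cytotoxicity, read by MTT assay, with a stated time of 48 h, tested at 100 uM; on this read-out lower numbers stand for less inhibition of growth and higher numbers for more inhibition of growth at the one concentration tested:
- compound 1 `C#CCNC(=O)Nc1cccc(COc2ccc(C(=O)OC)cc2)c1` gives 30%
- compound 2 `C#CCNC(=O)Nc1cccc(CNCc2ccc(C)cc2)c1` gives 30%
- compound 3 `C#CCNC(=O)Nc1cccc(CNCc2ccc(OC(F)(F)F)cc2)c1` gives 30%

All three compounds stand level on these numbers, so compound 3 sits neither ahead of nor behind the other two. The compound still to be measured, compound 4 `C#CCNC(=O)Nc1cccc(CNCc2ccc(OC)cc2)c1`, differs from compound 3 in one group: methyl in place of trifluoromethyl on an oxygen on an aromatic ring. Put simply, methyl takes the place of trifluoromethyl on an oxygen on an aromatic ring, which turns trifluoromethoxy into methoxy.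

Among the compounds with values here, one measured step bears on this change. It reads no change at the digits printed from compound 2 to compound 3 (within the scatter) and there trifluoromethoxy took the place of methyl on an aromatic carbon. Within the data shown here, that step is only a loose guide, since no compound with a methoxy group has been measured yet. Even so, it gives no reason to expect a shift in either direction, so no step beyond the scatter is expected. The expected change is no change at the digits printed from compound 3 to compound 4 (within the scatter) in this assay on this estimate. Compound 4 is estimated at 30% with an expected range from 20% to 40% in this assay once it is tested.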

Compound 4, percent growth inhibition at one concentration: 30%
Estimate against measurement, compound 4: no gap at the digits printed, and the stated range covers the measured number.
By their numbers in this assay, from the lowest: compounds 1, 2, 3 and 4 (each within the scatter of the next).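

In this assay, putting methyl in place of trifluoromethyl on an oxygen on an aromatic ring gives no change at the digits printed from compound 3 to compound 4 (within the scatter), so changing only the outer group on that oxygen leaves the read-out level. Methoxy in place of methyl on an aromatic carbon gives no change at the digits printed from compound 2 to compound 4 (within the scatter), which means that methyl, trifluoromethoxy and methoxy now all read alike at this place on the shared core. No supporting measurement is available to explain this sameness.

From the compounds shown here alone, all of these readings come from a single tested concentration, so any differences that might appear at other concentrations remain open. Going by these compounds, how an amine, a carboxylic acid or a longer chain on the oxygen would read at this place also remains open.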